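A few compounds are considered here, and "the series" means these few. Any claim that something is new, unique, unknown or untested is made for them only; others in the source may bear on it.

Measured in a functional assay on Huh-7 cells (Homo sapiens) for inhibition, read by MTT assay, with a stated time of 48 h; on this read-out lower numbers stand for stronger inhibition and higher numbers for weaker inhibition:

- Compound 1 `COc1ccc2c(=O)c(/C=C/C(=O)Nc3cccc(C)c3)coc2c1`: 15500 nM
- Compound 2 `COc1ccc2c(=O)c(/C=C/C(=O)Nc3ccccc3Cl)coc2c1`: 58400 nM
- Compound 3 `COc1ccc2c(=O)c(/C=C/C(=O)Nc3cc(C)ccc3C)coc2c1`: 11100 nM

Compound 3 sits at the low end of this small set. Its gap to compound 1 is small, as a 1.4-fold lower number from compound 1 to compound 3 (0.15 log units; within the scatter) stays within the scatter, whereas a 5.3-fold lower number from compound 2 to compound 3 (0.72 log units; beyond the scatter) goes beyond it.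

The next compound, compound 4 `COc1ccc(NC(=O)/C=C/c2coc3cc(OC)ccc3c2=O)cc1`, keeps the shared core and changes only the aromatic group: 4-methoxyphenyl in place of 2,5-dimethylphenyl on an amide-type nitrogen. This places 4-methoxyphenyl in place of 2,5-dimethylphenyl on an amide-type nitrogen. None of the three measured compounds carries 4-methoxyphenyl, so the data offer no direct guide. The nearest evidence is the other swaps of this group, a 3.8-fold higher number from compound 1 to compound 2 (0.58 log units; beyond the scatter) and a 5.3-fold lower number from compound 2 to compound 3 (0.72 log units; beyond the scatter), both modest. A step of about that size or smaller therefore seems likely, and since compound 3 already sits at the low end, a higher number is the more likely direction. The expected change is a 1.8-fold higher number from compound 3 to compound 4 (0.26 log units; within the scatter), which is only a small move. For compound 4 the estimated value is 20000 nM, with an expected range of 7000 nM to 55000 nM.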

Compound 4, half-maximal inhibitory concentration: > 100000 nM
Compound 4: only a limit was reported; the forecaster's own chance of this, stated with the estimate: 5%; middle value at least 5.0-fold (0.69 log units) away from the limit.
By their numbers in this assay, from the lowest: compounds 3 and 1 (each within the scatter of the next); then compound 2. At a limit, above all of these: compound 4.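

In this assay compound 4 gives only a limit of the assay, not a number: the limit of > 100000 nM in this assay, at which 1 of the 4 values shown sits. Placing 4-methoxyphenyl on the amide-type nitrogen gives an at least 9.0-fold higher number from compound 3 to compound 4 (0.95 log units; beyond the scatter) and an at least 6.4-fold higher number from compound 1 to compound 4 (0.80 log units; beyond the scatter), both beyond the scatter, whereas an at least 1.7-fold higher number from compound 2 to compound 4 (0.23 log units; that floor lies within the scatter) has a floor within the scatter, so compound 4 cannot be firmly placed above compound 2. Among these compounds, a single swap of the aromatic group at this nitrogen can therefore reach the limit of the assay, a larger step than the earlier swaps could show.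

From the compounds shown here alone, how far compound 4 lies past that limit remains unknown, and one compound cannot tie the change to the methoxy group. Going by these compounds, it also remains open how a phenyl ring carrying a hydroxyl or a fluorine in place of methoxy would behave.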